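Shortening the Side Chain of a Non-Toxic Compound

The compounds below may be only part of what the source reports. "The series", "measured", "known", "first", "only" and "open" are said of these compounds alone.

Compound 1, `CCCCCNc1cnc(C(=O)NCc2ccccc2)cn1`: in this test only a limit, > 100000 nM
Compound 2, `CCCCCCCCNc1nccnc1C(=O)NCc1ccccc1`: in this test only a limit, > 100000 nM

In an ADME assay on HeLa cells (Homo sapiens) for cytotoxicity, read by microscopy, with a stated time of 6 days (on this read-out higher numbers stand for lower toxicity in this test and lower numbers for higher toxicity in this test), compound 1 gives no number but the limit of the test, > 100000 nM. Compound 2 likewise stops at the limit, > 100000 nM. Compound 2 thus stands where every value shown stands, at the ceiling of the test (the limit of > 100000 nM in this assay, at which 2 of the 2 values shown sit), so no toxicity was seen for it within the range examined.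

Compound 3, `CCCCNc1nccnc1C(=O)NCc1ccccc1`, differs from compound 2 in one place: hydrogen in place of butyl on a saturated chain carbon, four bonds along the chain from a nitrogen on an aromatic ring. Going by the values given here, no pair of measured compounds that differ in a single place is available, so nothing shows how a change of this kind moves the read-out. Given that, the step of a number no higher from compound 2 to compound 3 (the limit leaves the size open) is expected to stay within the ordinary scatter, in no clear direction. Compound 3 is therefore expected to give about 100000 nM, with a likely range of 30000 nM to 300000 nM, and most probably again only the limit of the test.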

Compound 3, minimum cytotoxic concentration: > 100000 nM
Compound 3 ended at the assay's limit (the forecaster's own chance of this, stated with the estimate: 85%); the middle value lies on the limit itself.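

Like compound 2, compound 3 stops at a limit of the test, > 100000 nM, so the step between these two compounds cannot be read. The compounds shown leave open whether changing the length of the side chain affects the read-out in this assay at all.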